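The compounds below may be only part of what the source reports. "The series", "measured", "known", "first", "only" and "open" are said of these compounds alone.

Within the data shown here, in a functional assay on HeLa cells (Homo sapiens) for inhibition, read by MTT assay, with a stated time of 72 h (on this read-out higher numbers stand for weaker inhibition and lower numbers for stronger inhibition), compound 2 `Nc1ncnc2c1c(-c1cnc3[nH]ccc3c1)nn2CCCCCCCCCC(=O)NO` gives 7560 nM, the only actual number available so far. Compound 1 `Nc1ncnc2c1c(-c1cnc3[nH]ccc3c1)nn2CCCCC(=O)NO` reads > 150000 nM, which is a limit of the assay and not a number. The structural change leading to compound 3 `Nc1ncnc2c1c(-c1cnc3[nH]ccc3c1)nn2CCCCCCC(=O)NO` is hydroxycarbamoyl in place of 3-(hydroxycarbamoyl)propyl on a saturated chain carbon, six bonds along the chain from an aromatic nitrogen. Among the measured compounds shown here, one measured step bears on this, an at least 19-fold lower number from compound 1 to compound 2 (1.29 log units; beyond the scatter), where 5-(hydroxycarbamoyl)pentyl took the place of hydroxycarbamoyl. Compound 3 undoes only part of that extension, so a clear move towards a higher number in this assay, meaning weaker inhibition, is expected, though a smaller one than that measured step. The expected change is a 4.6-fold higher number from compound 2 to compound 3 (0.67 log units; beyond the scatter). For compound 3 the estimated value is 35000 nM, with an expected range of 12000 nM to 120000 nM.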

Compound 3, half-maximal inhibitory concentration: 22000 nM
For compound 3 the middle estimate is 1.6-fold (0.20 log units) above the measured one; the measured number falls inside the stated range.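

Shortening the chain at this position does not take the read-out straight to the limit: the change gives a 2.9-fold higher number from compound 2 to compound 3 (0.46 log units; beyond the scatter), so the intermediate chain still yields a measurable number. Lengthening the shortest chain already has a clear effect, with an at least 6.8-fold lower number from compound 1 to compound 3 (0.83 log units; beyond the scatter), and the three compounds now fall in one order, with the number dropping as the chain grows and none going against it. Compound 1 remains a limit of the assay and not a number, so the full size of that drop cannot be stated: the limit of > 150000 nM in this assay, at which 1 of the 3 values shown sits.

The compounds shown leave open whether a longer chain than that of compound 2 would lower the number further or raise it again. They also leave open how much depends on the hydroxycarbamoyl end itself, which a carboxylic acid at the chain end would test.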